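The source may hold more compounds than are shown below. What is called first, only, known or untested is meant among the compounds shown, and "the series" means these compounds.

Working notes on the series. For the measured compounds named here, compound 1 `Cc1ccccc1CN(C)C(=O)c1cc2c(Cc3ccccc3)n[nH]c2cc1O` is the one member of the set with a single number: in a functional assay on A2780 cells (Homo sapiens) for antiproliferative activity, read by resazurin assay, with a stated time of 72 h (a lower number here means a stronger inhibitor, a higher number a weaker inhibitor), compound 1 gives 4400 nM. Compound 2 `CN(Cc1cccc(C(F)(F)F)c1)C(=O)c1cc2c(Cc3ccccc3)n[nH]c2cc1O` carries no result in this assay; for compound 2 the entry reads "not determined" (no result reported), so nothing can be drawn from it. Compound 3 `COc1cc(CN(C)C(=O)c2cc3c(Cc4ccccc4)n[nH]c3cc2O)ccc1Cl` is still to be measured in this assay. The change from compound 1 to compound 3 is 4-chloro-3-methoxyphenyl in place of 2-methylphenyl on a saturated chain carbon bound to an amide-type nitrogen. Going by the values given here, no step between two measured compounds is available, so there is no precedent for this exchange on the shared core. Compound 1 with its 4400 nM is the only anchor. The expected step of a 1.5-fold lower number from compound 1 to compound 3 (0.17 log units; within the scatter) is small, within the scatter or at most a modest shift, with no firm direction. Compound 3 is therefore estimated at 3000 nM in this assay, with a range from 900 nM to 10000 nM.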

Compound 3, half-maximal inhibitory concentration: 4100 nM
Beside the measured number, compound 3's estimate is 1.4-fold (0.14 log units) below it, within the range that was stated.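

In this assay, for the compounds shown here, 4-chloro-3-methoxyphenyl in place of 2-methylphenyl on a saturated chain carbon bound to an amide-type nitrogen gives a 1.1-fold lower number from compound 1 to compound 3 (0.03 log units; within the scatter), the first step that can be read at this place on the shared core. The exchange brings in more heavy atoms, a chlorine, and a hydrogen-bond acceptor where 2-methylphenyl has none, yet the read-out does not move beyond the scatter, although this single pair sets no trend. No supporting measurement bears on this result.

Steps involving compound 2 cannot be read, so its trifluoromethyl group adds nothing here. Compound 1 and compound 3 both carry a substituted phenyl ring at this place, which leaves open how an amine or a carboxylic acid on that ring, or a longer chain in place of the benzyl group, would read.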